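Working notes: methoxy in place of chloro, compound 4

The source may report more compounds than this note shows. Statements on the series, on what has been measured and on what is new or still open speak of the compounds shown alone.

compound 1 `O=C(/C=C/c1cccc(OCc2ccccc2)c1)c1ccc(O)cc1`: 8100 nM
compound 2 `O=C(/C=C/c1cccc(OCc2ccccc2)c1)c1ccc(Cl)cc1`: 43600 nM
compound 3 `O=C(/C=C/c1cccc(OCc2ccccc2)c1)c1ccccc1Br`: 9100 nM

All three values come from an ADME assay on CHO cells (Cricetulus griseus) for cytotoxicity, read by MTT assay, with a stated time of 68 h; a higher number here means a weaker inhibitor, a lower number a stronger inhibitor. Compound 2 has the highest number of the three at 43600 nM, so it is the weakest inhibitor here. The change under consideration is methoxy in place of chloro on an aromatic carbon, and it gives compound 4 `COc1ccc(C(=O)/C=C/c2cccc(OCc3ccccc3)c2)cc1`, which has not yet been measured.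

Two modest steps, both beyond the scatter, bear on it. The first is a 5.4-fold higher number from compound 1 to compound 2 (0.73 log units; beyond the scatter), with chloro in place of hydroxy. The second is a 4.8-fold lower number from compound 2 to compound 3 (0.68 log units; beyond the scatter), with 2-bromophenyl in place of 4-chlorophenyl. By contrast, a 1.1-fold higher number from compound 1 to compound 3 (0.05 log units; within the scatter) lies within the scatter. For the measured compounds named here, both replacements of the 4-chlorophenyl group on record therefore end at a lower number, though that rests on three compounds and no methoxy compound has been measured. The expected change is a 2.4-fold lower number from compound 2 to compound 4 (0.38 log units; beyond the scatter), a lower number but a smaller step than those two. The estimate for compound 4 is 18000 nM, with an expected range of 7000 nM to 45000 nM.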

Compound 4, half-maximal inhibitory concentration: 22900 nM
Compound 4: the middle estimate sits 1.3-fold (0.10 log units) below what was measured; the range from low to high includes it.
By their numbers in this assay, from the lowest: compounds 1 and 3 (each within the scatter of the next); then compounds 4 and 2 (each within the scatter of the next).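

Methoxy in place of chloro on this aromatic carbon, para to a large group, does not separate the two compounds in this assay, where the result is a 1.9-fold lower number from compound 2 to compound 4 (0.28 log units; within the scatter) and is the first replacement of the 4-chlorophenyl group here that stays within the scatter. The hydroxy and methoxy groups at this place can be told apart, with methyl in place of hydrogen on the oxygen giving a 2.8-fold higher number from compound 1 to compound 4 (0.45 log units; beyond the scatter), and the 4-methoxyphenyl and 2-bromophenyl groups also differ, with a 2.5-fold higher number from compound 3 to compound 4 (0.40 log units; beyond the scatter) as the step. No measurement on hand bears on the cause of these steps.

Open, going by these compounds, is how an amine or a carboxylic acid at this aromatic carbon would compare with hydroxy and methoxy, and whether a longer chain on the oxygen, such as ethoxy, would extend the step from hydroxy to methoxy. Also open, on these data alone, is how a 4-bromophenyl group would compare with the 2-bromophenyl group. For the compounds shown here, no compound here has that 4-bromophenyl group.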